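Sulfinyl in place of sulfonyl on the chain

The compounds below may be only part of what the source reports. "The series", "measured", "known", "first", "only" and "open" are said of these compounds alone.

Measured so far in a functional assay on the whole organism with Rattus norvegicus as the target; on this read-out lower numbers stand for an effect already at smaller amounts and higher numbers for an effect only at larger amounts of compound: compound 1 `Cn1c(=N)sc2cc(OC(F)(F)F)ccc21` gives 5 mg/kg; compound 2 `CS(=O)(=O)CCn1c(=N)sc2cc(OC(F)(F)F)ccc21` gives 1.8 mg/kg. Compound 2 stands at the lower of the two numbers, with compound 1 the nearest at a 2.8-fold lower number from compound 1 to compound 2 (0.44 log units; beyond the scatter).

Compound 3 `CC[S+]([O-])CCn1c(=N)sc2cc(OC(F)(F)F)ccc21` differs from compound 2 by a group of 4 heavy atoms (2 carbon, 1 oxygen, 1 sulfur; no ring) in place of a group of 4 heavy atoms (1 carbon, 2 oxygen, 1 sulfur; no ring), on a saturated chain carbon, two bonds along the chain from an aromatic nitrogen. Among the measured compounds shown here, no measured step bears directly on this exchange; the only step, a 2.8-fold lower number from compound 1 to compound 2 (0.44 log units; beyond the scatter), concerns adding the chain itself. For this assay a step of a 1.2-fold higher number from compound 2 to compound 3 (0.09 log units; within the scatter) is therefore expected, with no clear direction and likely within the scatter. Compound 3 is estimated at 2.2 mg/kg, range 0.9 mg/kg to 5.5 mg/kg.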

Compound 3, dose for half-maximal effect: 1.2 mg/kg
Beside the measured number, compound 3's estimate is 1.8-fold (0.26 log units) above it; measured number inside the range.
By their numbers in this assay, from the lowest: compounds 3 and 2 (each within the scatter of the next); then compound 1.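

In this assay, the sulfinyl group in place of methylsulfonyl, on a saturated chain carbon, two bonds along the chain from an aromatic nitrogen, gives a 1.5-fold lower number from compound 2 to compound 3 (0.18 log units; within the scatter), so this exchange at sulfur leaves the number within the scatter. The gain from adding a chain persists with the new group, at a 4.2-fold lower number from compound 1 to compound 3 (0.62 log units; beyond the scatter). No measured evidence accounts for either step.

On these data alone, whether a sulfur group on the chain is needed at all remains open. An amine, a carboxylic acid or a longer chain at this place could keep or lose that gain.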